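A few compounds are considered here, and "the series" means these few. Any claim that something is new, unique, unknown or untested is made for them only; others in the source may bear on it.

Measured so far: compound 1 `COc1cc(-c2cc(/C=C/C(=O)c3ccc(N)cc3)[nH]n2)cc(OC)c1OC` with -84% in a functional assay on COLO 205 cells (Homo sapiens) for cytotoxicity, read by sulforhodamine B assay, with a stated time of 48 h, tested at 10 uM (on this read-out higher numbers stand for a weaker effect at the one concentration tested and lower numbers for a stronger effect), and compound 2 `COc1cc(-c2cc(/C=C/C(=O)c3ccc(Cl)c(Cl)c3)[nH]n2)cc(OC)c1OC` with 10%.

Compound 2 thus stands highest of the two numbers; its nearest neighbour is compound 1, separated by a number 94 percentage points higher from compound 1 to compound 2 (beyond the scatter). Compound 3 `COc1ccc(C(=O)/C=C/c2cc(-c3cc(OC)c(OC)c(OC)c3)n[nH]2)cc1OC` differs from compound 2 by 3,4-dimethoxyphenyl in place of 3,4-dichlorophenyl on a carbonyl carbon. Going by the values given here, no measured step matches this change directly; the one step known, 3,4-dichlorophenyl in place of 4-aminophenyl on a carbonyl carbon, was large, and it shows that groups on this carbonyl carbon can move this assay far. For compound 3 a step of a number 40 percentage points lower from compound 2 to compound 3 (beyond the scatter) is therefore expected, and compound 3 is estimated at -30%, between -80% and 20%.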

Compound 3, a percentage reported as activity, at one concentration (the size of the read-out at that concentration, not a potency): -93%
Beside the measured number, compound 3's estimate is 63 percentage points above it; the measured number lies below the stated range.
By their numbers in this assay, from the lowest: compounds 3 and 1 (each within the scatter of the next); then compound 2.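

Changing 3,4-dichlorophenyl to 3,4-dimethoxyphenyl on the carbonyl carbon moves this assay by a large amount, with a number 103 percentage points lower from compound 2 to compound 3 (beyond the scatter) in this change. The 4-aminophenyl and 3,4-dimethoxyphenyl groups cannot be told apart here, with a number 9 percentage points lower from compound 1 to compound 3 (within the scatter) between them, so among these compounds only the 3,4-dichlorophenyl of compound 2 stands apart. Nothing shown gives a reason for this separation. From the compounds shown here alone, it remains open whether a single methoxy group or a hydroxyl group on this phenyl ring would give a number like that of compound 2 or that of compound 3.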